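Nitro on the phenylpiperazine of a chalcone amide

A few compounds are considered here, and "the series" means these few. Any claim that something is new, unique, unknown or untested is made for them only; others in the source may bear on it.

Measured compounds:
compound 1 `CCCCCCCCCCn1cc(/C=C/C(=O)c2ccc(NC(=O)CN3CCN(c4ccccc4)CC3)cc2)nn1` 59100 nM
compound 2 `CCCCCCCCCCn1cc(/C=C/C(=O)c2ccc(NC(=O)CBr)cc2)nn1` 7410 nM

In a functional assay on HeLa cells (Homo sapiens) for inhibition, read by MTT assay (on this read-out higher numbers stand for weaker inhibition and lower numbers for stronger inhibition), compound 1 gives the highest of the two numbers; its nearest neighbour is compound 2, reached by an 8.0-fold lower number from compound 1 to compound 2 (0.90 log units; beyond the scatter). Compound 3 `CCCCCCCCCCn1cc(/C=C/C(=O)c2ccc(NC(=O)CN3CCN(c4ccc([N+](=O)[O-])cc4)CC3)cc2)nn1` differs from compound 1 by nitro in place of hydrogen on an aromatic carbon. Going by the values given here, no measured step touches the phenyl ring of the piperazine: the one step known changes the whole chain end, so it does not bear on this change. For compound 3 the expectation is therefore a 1.2-fold lower number from compound 1 to compound 3 (0.07 log units; within the scatter), not beyond the scatter. Compound 3 is estimated at 50000 nM, within 15000 nM to 150000 nM.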

Compound 3, half-maximal inhibitory concentration: 65900 nM
Compound 3: the middle estimate sits 1.3-fold (0.12 log units) below what was measured, and the stated range covers the measured number.
By their numbers in this assay, from the lowest: compound 2; then compounds 1 and 3 (each within the scatter of the next).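

In this assay, phenyl to 4-nitrophenyl gives a 1.1-fold higher number from compound 1 to compound 3 (0.05 log units; within the scatter), so the two numbers cannot be told apart. Nitro on this aromatic carbon, para to a large group, therefore brings no step beyond the scatter, although it adds 3 heavy atoms to the end of the chain. No measurement at hand offers a reason for this result.

Open, from the compounds shown here alone, is whether an amine or a carboxylic acid on the same aromatic carbon would also read like compound 1. Also open, going by these compounds, is whether a single fluorine there would do the same.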